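The compounds below may be only part of what the source reports. "The series", "measured", "known", "first", "only" and "open" are said of these compounds alone.

Measured so far:
compound 1, `CCCCCc1ccc(OCC(=O)Nc2cccc(C(=O)OC)c2)cc1` — 6790 nM in an assay for inhibition of malate dehydrogenase, cytoplasmic (Homo sapiens), with a stated time of 30 min; on this read-out lower numbers stand for stronger inhibition and higher numbers for weaker inhibition
compound 2, `C#CCN1CCN(C(=O)COc2ccc(C(C)(C)CC(C)(C)C)cc2)CC1` — > 40000 nM in this assay

Within the data shown here, compound 1 is the only compound with a numbered result; in this assay compound 1 gives 6790 nM. Compound 2 reaches only a limit of the assay, not a number: in this assay compound 2 gives > 40000 nM, which is the limit of > 40000 nM in this assay, at which 1 of the 2 values shown sits. Among the measured compounds shown here, nothing else in the data shows how the two relate, because no step between them is given.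

Compound 3 is `CCCc1ccc(OCC(=O)Nc2cccc(C(=O)OC)c2)cc1` and has not yet been measured. It differs from compound 1 by hydrogen in place of ethyl on a saturated chain carbon, three bonds along the chain from an aromatic carbon. The chain on the ring of compound 1 is shortened, pentyl to propyl, and the rest of the structure stays the same.

For the measured compounds named here, no measured pair differs in just one place, so the expected size of this step rests on the structural change alone. A shortening of the chain is expected to weaken inhibition somewhat, by a step of a 1.9-fold higher number from compound 1 to compound 3 (0.28 log units; within the scatter) in this assay, which goes a little beyond the usual scatter but not far. Compound 3 is therefore estimated at 13000 nM in this assay, with a likely range from 5000 nM to 35000 nM.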

Compound 3, half-maximal inhibitory concentration: > 40000 nM
Compound 3: a limit, no number; the forecaster's own chance of this, stated with the estimate: 25%; middle value at least 3.0-fold (0.48 log units) from the limit.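

Cutting the pentyl chain back to propyl, with the rest of the structure unchanged, gives an at least 5.8-fold higher number from compound 1 to compound 3 (0.77 log units; beyond the scatter) in this assay. This shows that the chain end is not a spare part in this series, since losing the ethyl end alone is enough to take away the measurable inhibition seen with the longer chain. Compound 3 gives > 40000 nM, which is a limit of the assay and not a number, so the true size of the step remains unknown, and the result joins a growing share of values that stop at the same limit: the limit of > 40000 nM in this assay, at which 2 of the 3 values shown sit.

From the compounds shown here alone, what remains open is how inhibition changes along the chain, for example whether a butyl chain would still give a numbered result or a longer chain such as heptyl would lower the number further than compound 1 does. The compounds shown also cannot tell whether length alone matters at this position, or whether a ring such as cyclohexyl or an amine at the chain end could take the place of the pentyl chain.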